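Swapping pyrimidin-2-yl for pyridin-2-yl on the shared core

The compounds below may be only part of what the source reports. "The series", "measured", "known", "first", "only" and "open" are said of these compounds alone.

Measured compounds in a functional assay on L5178Y cells (Mus musculus) for cytotoxicity, read by MTT assay; on this read-out higher numbers stand for weaker inhibition and lower numbers for stronger inhibition
- compound 1 `CCC(=O)c1ccc(OCCCN2CCN(c3ncccn3)CC2)cc1` gives > 100 nM (a limit of the assay)
- compound 2 `CC(C)(C)c1ccc(OCCCN2CCN(c3ncccn3)CC2)cc1` gives 40.4 nM (a number)
- compound 3 `CC(C)(C)c1ccc(OCCCCN2CCN(c3ncccn3)CC2)cc1` gives 20.8 nM (a number)

Compound 1 is reported only as a limit, > 100 nM (no number). Among the compounds with values here, compound 3, at 20.8 nM (its measured number), stands within the usual scatter of compound 2 at 40.4 nM (the only other number), so the two cannot be told apart in this assay here.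

Compound 4 `CC(C)(C)c1ccc(OCCCCN2CCN(c3ccccn3)CC2)cc1` is not yet measured. It carries pyridin-2-yl in place of pyrimidin-2-yl on an amine nitrogen in a ring.

Within the data shown here, the one measured step between compounds differing in one place is an at least 2.4-fold lower number from compound 1 to compound 2 (0.39 log units; beyond the scatter) (tert-butyl in place of propanoyl on an aromatic carbon). That step rests on the limit of > 100 nM in this assay, at which 1 of the 3 values shown sits, and changes a different group, so it bears only weakly on this change. Among the measured compounds shown here, no measured step touches the pyrimidin-2-yl group itself, and the expectation therefore starts from compound 3 at 20.8 nM (the closest relative). The expected change is a 1.1-fold lower number from compound 3 to compound 4 (0.04 log units; within the scatter) (no step beyond the scatter, in either direction). The estimated value for compound 4 is 19 nM (expected range 8 nM to 50 nM).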

Compound 4, half-maximal inhibitory concentration: 15.1 nM
Beside the measured number, compound 4's estimate is 1.3-fold (0.10 log units) above it, and the stated range covers the measured number.
By their numbers in this assay, from the lowest: compounds 4, 3 and 2 (each within the scatter of the next, the first and the last beyond it). At a limit, above all of these: compound 1.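

In this assay, within the data shown here, the swap gives the first reading on the group at the amine nitrogen in a ring, which all the earlier compounds held constant as pyrimidin-2-yl: a 1.4-fold lower number from compound 3 to compound 4 (0.14 log units; within the scatter). A ring with 2 hetero atoms and 2 hydrogen-bond acceptors thus gives way to one with 1 hetero atom and 1 hydrogen-bond acceptor, with no change that this assay can separate from repeat scatter, so on this core, with its tert-butyl group and its chain, the second ring nitrogen of pyrimidin-2-yl is not needed to keep the number in this range. The values shown offer no measured property that would explain this result.

Still open, as far as these compounds go, is whether a phenyl group, with no ring nitrogen at all, or a pyridin-4-yl group, with its ring nitrogen placed elsewhere, would hold the number at this position on the amine nitrogen. Among these compounds, it is also open whether pyridin-2-yl would behave the same way on a core carrying a propanoyl group in place of tert-butyl, or a longer chain than the one in this pair.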